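The compounds below may be only part of what the source reports. "The series", "measured", "known", "first", "only" and "open" are said of these compounds alone.

Measured compounds:
compound 1 `CC(=O)C1=C(C)NC(=O)NC1c1ccoc1` — 6%
compound 2 `CC(=O)C1=C(C)NC(=O)NC1c1ccsc1` — 9%

In an assay on membranes from CHO cells for displacement of a labelled ligand from adenosine receptor A1 (Homo sapiens), read by scintillation counting, with a stated time of 60 min, tested at 1 uM (a lower number here means less inhibition, a higher number more inhibition at the concentration tested (going by the name of the read-out)), compound 1 gives 6% and compound 2 gives 9%; the two numbers lie within the usual scatter of each other, so neither compound can be set apart from the other on this read-out. For the measured compounds named here, the only measured step, a number 3 percentage points higher from compound 1 to compound 2 (within the scatter), concerns the group on the saturated ring carbon and says nothing about the double-bonded ring carbon.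

Compound 3 `CC1=C(c2ncc(C)o2)C(c2ccsc2)NC(=O)N1` differs from compound 2 in 5-methyl-1,3-oxazol-2-yl in place of acetyl on a double-bonded ring carbon. Going by the values given here, no measured pair shows this exchange, so no step bears directly on it; the only guide is that both measured compounds sit low in this assay and that the one exchange measured moved nothing beyond the scatter. For compound 3 the expected step is therefore a number 3 percentage points higher from compound 2 to compound 3 (within the scatter), not beyond the scatter, with a wider range allowed for movement in either direction. Compound 3 is expected to give 12% in this assay, within 0% to 35%.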

Compound 3, a percentage reported as inhibition, at one concentration (the size of the read-out at that concentration, not a potency): 34%
The estimate for compound 3 lay 22 percentage points below the measured number, and the stated range covers the measured number.
By their numbers in this assay, from the lowest: compounds 1 and 2 (each within the scatter of the next); then compound 3.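

In this assay, for the compounds shown here, the double-bonded ring carbon is the first place where a change gives a step beyond the scatter: 5-methyl-1,3-oxazol-2-yl in place of acetyl, with thiophen-3-yl kept on the saturated ring carbon, gives a number 25 percentage points higher from compound 2 to compound 3 (beyond the scatter). The earlier exchange on the saturated ring carbon, a number 3 percentage points higher from compound 1 to compound 2 (within the scatter), stayed within the scatter, so the two compounds before this one gave no sign that the series could move on this read-out at all; the step is modest, and compound 3 at 34% is a reading at one concentration, not a potency. No measurement at hand bears on the origin of this step.

As far as these compounds go, it remains open whether a 1,3-oxazol-2-yl without the methyl group, or a methyl ester in place of acetyl, would give a number near that of compound 3, so the step cannot yet be assigned to the new ring, to its methyl group or simply to the loss of acetyl. From the compounds shown here alone, it also remains open whether the same exchange would give a similar step with furan-3-yl on the saturated ring carbon.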